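From Cyclohexyl to Methoxyphenyl: Expected Cytotoxicity of Compound 4

The source may hold more compounds than are shown below. What is called first, only, known or untested is meant among the compounds shown, and "the series" means these compounds.

Of the compounds shown here, three sharing one core have been tested in an ADME assay on HepG2 cells (Homo sapiens) for cytotoxicity, read by MTT assay, with a stated time of 48 h; a higher number here means a weaker inhibitor, a lower number a stronger inhibitor. Compound 1 `O=[N+]([O-])c1cc(CSc2nnnn2C2CCCCC2)cc([N+](=O)[O-])c1` reaches only the limit of this assay, > 30000 nM. Compound 2 `O=[N+]([O-])c1cc(C[Se]c2nnnn2Cc2ccccc2)cc([N+](=O)[O-])c1` gives a measured number, 16500 nM. Compound 3 `O=[N+]([O-])c1cc(C[Se]c2nnnn2C2CCCCC2)cc([N+](=O)[O-])c1` again sits at the limit, > 30000 nM. Compound 3 therefore stands at the edge of what this assay can report, where (the limit of > 30000 nM in this assay, at which 2 of the 3 values shown sit), while compound 2 alone yields a number inside the measurable range.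

The step to compound 4 `COc1ccc(-n2nnnc2[Se]Cc2cc([N+](=O)[O-])cc([N+](=O)[O-])c2)cc1` is 4-methoxyphenyl in place of cyclohexyl on an aromatic nitrogen. Within the data shown here, the one measured step at the same place, an at least 1.8-fold higher number from compound 2 to compound 3 (0.25 log units; that floor lies within the scatter), exchanged a benzyl for the cyclohexyl and moved the result from a number to a limit. Returning to an aromatic group on that nitrogen, compound 4 is expected to land near the region of compound 2, so the step of an at least 1.5-fold lower number from compound 3 to compound 4 (0.17 log units; that floor lies within the scatter) is estimated to be small, possibly within the scatter. The estimate for compound 4 in this assay is 20000 nM, between 8000 nM and 60000 nM.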

Compound 4, half-maximal inhibitory concentration: 19000 nM
For compound 4 the middle estimate is 1.1-fold (0.02 log units) above the measured one; measured number inside the range.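

In this assay the change from cyclohexyl to 4-methoxyphenyl gives an at least 1.5-fold lower number from compound 3 to compound 4 (0.19 log units; that floor lies within the scatter) and brings a number inside the measurable range to this position on the aromatic nitrogen. Compared with benzyl, 4-methoxyphenyl gives a 1.2-fold higher number from compound 2 to compound 4 (0.06 log units; within the scatter) and the two groups cannot be told apart here. The first of these steps is only a floor, because compound 3 sits at a limit of the assay: the limit of > 30000 nM in this assay, at which 2 of the 4 values shown sit.

On these data alone, how far the true value of compound 3 lies beyond that limit remains open, so the full size of the step to compound 4 is unknown. The compounds shown also leave open what a plain phenyl would give on this nitrogen, and whether an amine or a carboxylic acid in place of the methoxy group would move the number.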